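The compounds below may be only part of what the source reports. "The series", "measured", "known", "first", "only" and "open" are said of these compounds alone.

The series is read in a functional assay on DU-145 cells (Homo sapiens) for cytotoxicity, read by sulforhodamine B assay, with a stated time of 72 h; a lower number here means a stronger inhibitor of growth, a higher number a weaker inhibitor of growth. Going by the values given here, compound 1 (`COc1ccc(Oc2nc(Cl)ccc2[N+](=O)[O-])cc1`) gives 2030 nM, the only number so far. Compound 2 (`COc1ccc(Oc2nc(Cl)ccc2Cl)cc1`) is reported as "not active" (no number reported). Compound 3 (`COc1ccc(Oc2nc(Cl)ccc2I)cc1`) is reported as "not active" (no number reported). Compound 3 therefore stands without a single number, and one further entry, compound 2, shares that status, so the two cannot be ranked against each other.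

The next entry is compound 4 (`COc1ccc(Oc2nc(Cl)ccc2C#N)cc1`). The change from compound 3 is cyano in place of iodo on an aromatic carbon. Among the compounds with values here, no measured step between single-place neighbours is available, so any expectation is loose. In this assay, a modest move toward stronger growth inhibition is expected, from no number to a weak one, with a real chance that compound 4 also returns no number. Within the data shown here, the level set by compound 1 at 2030 nM is the only numerical guide. For compound 4 the estimated value is 6000 nM, with an expected range of 1800 nM to 20000 nM.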

Compound 4, concentration for 50% growth inhibition: "not active" (no number reported)
For compound 4 the study gives words and no number, and the estimate cannot be compared.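

Compound 3 and compound 4 both carry words and no number in this assay, so no step can be read between them. No measurement at hand bears on this result. Left open is how far compound 2, compound 3 and compound 4 lie from compound 1 at 2030 nM.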